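Swapping an Isopropyl for a Cyclopropyl on the Pyrrolidine

The compounds below may be only part of what the source reports. "The series", "measured", "known", "first", "only" and "open" are said of these compounds alone.

Three compounds share one core and differ only in the group on the amide-type nitrogen. Compound 1 `O=C(N[C@@H]1CCNC1)c1cc(-c2ccc(NS(=O)(=O)c3cccc(Cl)c3Cl)cc2)nc2[nH]ncc12` carries a plain pyrrolidin-3-yl group; in an assay for inhibition of serine/threonine-protein kinase Sgk1 (Homo sapiens), with stated times of 30 min and 60 min, in the presence of a further agent that is not named here (a higher number here means a weaker inhibitor, a lower number a stronger inhibitor), compound 1 gives < 1 nM, which is a limit of the assay rather than a number. Compound 2 `CN1CCC(NC(=O)c2cc(-c3ccc(NS(=O)(=O)c4cccc(Cl)c4Cl)cc3)nc3[nH]ncc23)C1` carries a 1-methylpyrrolidin-3-yl group and gives 21 nM. Compound 3 `CC(C)N1CC[C@H](NC(=O)c2cc(-c3ccc(NS(=O)(=O)c4cccc(Cl)c4Cl)cc3)nc3[nH]ncc23)C1` carries a 1-isopropylpyrrolidin-3-yl group and gives 38 nM, the higher of the two numbers shown, although the step of a 1.8-fold higher number from compound 2 to compound 3 (0.26 log units; within the scatter) is within the scatter. By contrast, both an at least 21-fold higher number from compound 1 to compound 2 (1.32 log units; beyond the scatter) and an at least 38-fold higher number from compound 1 to compound 3 (1.57 log units; beyond the scatter) are large. Compound 4 `O=C(NC1CCN(C2CC2)C1)c1cc(-c2ccc(NS(=O)(=O)c3cccc(Cl)c3Cl)cc2)nc2[nH]ncc12` is not yet measured; its change from compound 3 is 1-cyclopropylpyrrolidin-3-yl in place of 1-isopropylpyrrolidin-3-yl on an amide-type nitrogen. Within the data shown here, only the step from compound 2 to compound 3 bears on an exchange of one alkyl group for another on that nitrogen, and it was small, so the expected step is a 1.3-fold lower number from compound 3 to compound 4 (0.10 log units; within the scatter), with no change beyond the scatter. Compound 4 is estimated at 30 nM, with a range from 12 nM to 90 nM.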

Compound 4, half-maximal inhibitory concentration: 610 nM
Compound 4: middle estimate off by 20-fold (1.31 log units), on the low side; measured number above the stated range.
By their numbers in this assay, from the lowest: compounds 2 and 3 (each within the scatter of the next); then compound 4. At a limit, below all of these: compound 1.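

In this assay, the group on the pyrrolidine nitrogen turns out not to be freely exchangeable: compound 2 and compound 3 lie within the scatter of each other, yet cyclopropyl gives a 16-fold higher number from compound 3 to compound 4 (1.21 log units; beyond the scatter) and a 29-fold higher number from compound 2 to compound 4 (1.46 log units; beyond the scatter). The small earlier step therefore did not carry over, even though isopropyl and cyclopropyl have the same count of heavy atoms, so which group sits on that nitrogen matters and not only whether one is there. The step of an at least 610-fold higher number from compound 1 to compound 4 (2.78 log units; beyond the scatter) rests on compound 1, whose value is a limit and not a number: the limit of < 1 nM in this assay, at which 1 of the 4 values shown sits.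

As far as these compounds go, whether the loss belongs to the three-membered ring alone stays open, and a cyclobutyl or oxetanyl group on that nitrogen would bear on this. Compound 3 has a defined stereocentre and compound 4 has none, so the effect of that difference also remains unresolved.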